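The source may hold more compounds than are shown below. What is called first, only, known or untested is meant among the compounds shown, and "the series" means these compounds.

Measured so far:
compound 1 `Cc1cn([C@@H]2O[C@H](CO[Si](C)(C)C(C)(C)C)[C@@]3(OS(=O)(=O)C=C3NCC(=O)C(=O)N3CCC3)[C@H]2O[Si](C)(C)C(C)(C)C)c(=O)n(C)c1=O`: 65000 nM
compound 2 `Cc1cn([C@@H]2O[C@@H]3COC(=O)[C@]3(OS(C)(=O)=O)[C@H]2O)c(=O)[nH]c1=O`: >= 400000 nM

Going by the values given here, in a functional assay on HEL cells (Homo sapiens) for cytotoxicity, read by microscopy (a higher number here means that more compound is tolerated, a lower number that less compound is tolerated), compound 1 gives 65000 nM and is the only compound here that returns a number. For compound 2 this assay returns only a limit, >= 400000 nM, which is the limit of >= 400000 nM in this assay, at which 1 of the 2 values shown sits. Among the compounds with values here, no two measured compounds differ in a single place, so no measured step is available to scale the change now under study.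

Compound 3 `COC(=O)CNC1=CS(=O)(=O)O[C@@]12[C@@H](CO[Si](C)(C)C(C)(C)C)O[C@@H](n1cc(C)c(=O)n(C)c1=O)[C@@H]2O[Si](C)(C)C(C)(C)C` comes from compound 1 by one change: methoxy in place of (azetidin-1-yl)carbonyl on a carbonyl carbon. The rest of the structure stays as in compound 1.

Within the data shown here, with no measured step to lean on, the expectation for compound 3 rests on the size of the change alone, which is a shortening at the end of the side chain. In this assay the step from compound 1 is estimated as a 1.2-fold higher number from compound 1 to compound 3 (0.09 log units; within the scatter), expected to stay within the scatter, with a slight lean toward more compound being tolerated. Compound 3 is therefore estimated at 80000 nM, with a range from 30000 nM to 250000 nM.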

Compound 3, minimum cytotoxic concentration: >= 400000 nM
Compound 3 ended at the assay's limit; the forecaster's own chance of this, stated with the estimate: 20%; middle value at least 5.0-fold (0.69 log units) from the limit.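

In this assay, going by these compounds alone, methoxy in place of (azetidin-1-yl)carbonyl on a carbonyl carbon gives an at least 6.1-fold higher number from compound 1 to compound 3 (0.78 log units; beyond the scatter), the first measured step, and it lies beyond the scatter. For compound 3 the reading of >= 400000 nM is a limit and not a number. The end of this side chain therefore affects how much compound is tolerated, and compound 1 remains the only compound with a numeric reading in this set: the limit of >= 400000 nM in this assay, at which 2 of the 3 values shown sit.

The compounds shown leave open whether the azetidine ring itself or the whole ((azetidin-1-yl)carbonyl)carbonyl end goes with the lower number in this assay, and how large the step really is. A dimethylamino group or a longer open-chain amine on that carbonyl carbon would separate the ring from the amide.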